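Bromine Swapped for Chlorine in a Growth Inhibition Series

A few compounds are considered here, and "the series" means these few. Any claim that something is new, unique, unknown or untested is made for them only; others in the source may bear on it.

Of the compounds shown here, three of one series have been tested in a functional assay on RPMI-8226 cells (Homo sapiens) for inhibition, read by sulforhodamine B assay, with a stated time of 48 h, tested at 10 uM; a higher number here means more inhibition of growth at the concentration tested, a lower number less inhibition of growth. Compound 1 `CC(=O)c1cccc(Nc2ccnc(SCC(=O)c3ccc(C(F)(F)F)cc3)n2)c1` gives 31%. Compound 2 `CCOC(=O)c1ccc(Nc2ccnc(SCC(=O)c3ccc([N+](=O)[O-])cc3)n2)cc1` gives 54%. Compound 3 `CC(=O)c1ccc(Nc2ccnc(SCC(=O)c3ccc(Br)cc3)n2)cc1` gives 35%, the second highest of the three numbers; the reading of compound 1 lies slightly lower and within the usual scatter, while the reading of compound 2 lies higher by a margin beyond the scatter. No two of these compounds differ in only one place, so no single measured step can be drawn from them.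

Compound 4 `CC(=O)c1ccc(Nc2ccnc(SCC(=O)c3ccc(Cl)cc3)n2)cc1` differs from compound 3 in one place: chloro in place of bromo on an aromatic carbon. Among the measured compounds shown here, nothing among the measured compounds shows this change, and the two groups are counted alike in size, donors and acceptors. The step of a number 3 percentage points lower from compound 3 to compound 4 (within the scatter) is therefore expected to be small, with no direction beyond the scatter. Because compound 3 gives 35% in this assay, compound 4 is expected to give 32%, in a range from 18% to 46%.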

Compound 4, percent growth inhibition at one concentration: 46%
Estimate against measurement, compound 4: 14 percentage points below; measured number inside the range.
By their numbers in this assay, from the lowest: compounds 1 and 3 (each within the scatter of the next); then compounds 4 and 2 (each within the scatter of the next).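

In this assay, the change from 4-bromophenyl to 4-chlorophenyl gives a number 11 percentage points higher from compound 3 to compound 4 (beyond the scatter), so the outcome at this position, on an aromatic carbon para to a large group, depends on which of these two halogens it carries, although the step is only modest. Among the compounds shown here, this is the first single change that can be read, as none of the earlier compounds differed in only one place. The two groups are counted alike in heavy atoms, donors and acceptors, and no measurement at hand explains the step.

From the compounds shown here alone, whether fluoro, a methoxy group or an amine at this carbon would extend the step remains open. A single pair also cannot show whether the same swap would give a similar step with other groups elsewhere on the shared core.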